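A Second Ring Methyl: What to Expect for Compound 4

This account rests on a few compounds, and the source may have more. Where it says the series, first, only, none or still open, it means among the compounds named here.

Compound 1, `CC(=O)Nc1ccc2[nH]c(C)nc2c1`: 1260000 nM
Compound 2, `Cc1ccc2[nH]c(C)nc2c1`: 479000 nM
Compound 3, `CCc1nc2cc(C)ccc2[nH]1`: 269000 nM

Of the compounds shown here, three sharing one core have so far been measured in an ADME assay on microsomes from liver for inhibition of cytochrome P450 2B1 (Rattus norvegicus); a higher number here means a weaker inhibitor, a lower number a stronger inhibitor. Compound 2 stands second highest among the three. Its nearest neighbour is compound 3, with a 1.8-fold lower number from compound 2 to compound 3 (0.25 log units; within the scatter), a gap that sits within the scatter; its furthest neighbour is compound 1, with a 2.6-fold lower number from compound 1 to compound 2 (0.42 log units; beyond the scatter), a gap that goes beyond it.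

The next compound, compound 4, `Cc1nc2c(C)c(C)ccc2[nH]1`, differs from compound 2 in a single place: methyl in place of hydrogen on an aromatic carbon.

Going by the values given here, two measured steps bear on this change, though neither repeats it exactly. Replacing the acetamido with a methyl gave a 2.6-fold lower number from compound 1 to compound 2 (0.42 log units; beyond the scatter), and adding a methyl on the chain gave a 1.8-fold lower number from compound 2 to compound 3 (0.25 log units; within the scatter). Among the compounds with values here, both methyl-bearing compounds gave lower numbers than their partners, but only one of these steps went beyond the scatter. Adding a methyl on an aromatic carbon has no direct precedent here, so the expectation is a small step toward a lower number, or none beyond the scatter: compound 4 is expected to show a 1.6-fold lower number from compound 2 to compound 4 (0.20 log units; within the scatter). The estimate for compound 4 in this assay is 300000 nM, within a range of 120000 nM to 800000 nM.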

Compound 4, half-maximal inhibitory concentration: 251000 nM
Compound 4: the middle estimate sits 1.2-fold (0.08 log units) above what was measured; the range from low to high includes it.
By their numbers in this assay, from the lowest: compounds 4, 3 and 2 (each within the scatter of the next); then compound 1.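

In this assay, putting a methyl in place of hydrogen on an aromatic carbon gives a 1.9-fold lower number from compound 2 to compound 4 (0.28 log units; within the scatter), so this position, ortho to a fused ring and ortho to a methyl group, accepts the added methyl with no shift that can be told from the scatter. The earlier compounds shown here showed this only for a methyl on the saturated chain carbon, with a 1.8-fold lower number from compound 2 to compound 3 (0.25 log units; within the scatter); now a methyl on the aromatic ring and a methyl on the chain each stay within the scatter of compound 2, so neither single addition separates from it. Nothing shown here gives a reason for this outcome.

The compounds shown leave open whether a larger or different group on this same aromatic carbon, such as an amine, a carboxylic acid or a longer chain, would move the number beyond the scatter. They also leave open whether a methyl on the other aromatic carbons of the six-membered ring would behave as this one does.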